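Chlorophenyl for methylphenyl swap on two related cores

The source may report more compounds than this note shows. Statements on the series, on what has been measured and on what is new or still open speak of the compounds shown alone.

Compound 1 `Cc1ccc(C(=O)NNC(=O)c2ccc(NS(=O)(=O)c3cnc(O)nc3O)cc2)cc1` and compound 3 `Cc1ccc(C(=O)NNC(=O)c2cccc(NS(=O)(=O)c3cnc(O)nc3O)c2)cc1` are built from the same atoms joined differently; the difference between the two cores is not broken down here. In a functional assay on MDA-MB-231 cells (Homo sapiens) for antiproliferative activity, read by MTT assay, with a stated time of 24 h (a higher number here means a weaker inhibitor, a lower number a stronger inhibitor), compound 1 reaches only a limit, > 20000 nM. Compound 3 likewise reaches only a limit in this assay, > 20000 nM. Compound 2 `O=C(NNC(=O)c1ccccc1Cl)c1ccc(NS(=O)(=O)c2cnc(O)nc2O)cc1` carries 2-chlorophenyl in place of 4-methylphenyl on a carbonyl carbon and gives 13900 nM in this assay. The resulting step, an at least 1.4-fold lower number from compound 1 to compound 2 (0.15 log units; that floor lies within the scatter), has its floor set by the limit of > 20000 nM in this assay, at which 2 of the 3 values shown sit. Compound 4 `O=C(NNC(=O)c1ccccc1Cl)c1cccc(NS(=O)(=O)c2cnc(O)nc2O)c1` is unmeasured and carries 2-chlorophenyl in place of 4-methylphenyl on a carbonyl carbon on the core of compound 3, the same kind of change at a place described in identical words. A step of about the size of an at least 1.4-fold lower number from compound 1 to compound 2 (0.15 log units; that floor lies within the scatter) is expected again, resting on that single measured pair, which itself only just cleared the limit. Compound 4 is therefore estimated at 18000 nM in this assay, meaning a step of an at least 1.1-fold lower number from compound 3 to compound 4 (0.04 log units; that floor lies within the scatter), with a real chance that only a limit is reported.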

Compound 4, half-maximal inhibitory concentration: 2360 nM
Compound 4: middle estimate off by 7.6-fold (0.88 log units), on the high side; the whole stated range lies above it.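

In this assay, 2-chlorophenyl in place of 4-methylphenyl on a carbonyl carbon gives an at least 8.4-fold lower number from compound 3 to compound 4 (0.92 log units; beyond the scatter), so on the core of compound 3 the change lowers the number by a step that clears the scatter. This shows that both measured pairs point the same way, but not that the change carries over with the same size: the same change on two cores in this assay, an at least 1.4-fold lower number (0.15 log units; that floor lies within the scatter) from compound 1 to compound 2 and an at least 8.4-fold lower number (0.92 log units; beyond the scatter) from compound 3 to compound 4; the limit leaves it open whether they differ. As far as these compounds go, both steps are floors, not full sizes, and the true size of each remains unknown: the limit of > 20000 nM in this assay, at which 2 of the 4 values shown sit.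

The compounds shown leave open whether this step depends on the chlorine itself or on the loss of the methyl group. They also leave open how a plain phenyl, or a phenyl carrying an amine or a carboxylic acid, would read on either core.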